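Aryl replacement on the biaryl carbon and cytotoxicity

The source may hold more compounds than are shown below. What is called first, only, known or untested is meant among the compounds shown, and "the series" means these compounds.

Measured so far:
compound 1 `CC(C)N(Cc1cccc(OCCCCCC(=O)O)c1)C(=O)c1ccc(-c2cccc3ccccc23)cc1`: < 1.3 nM
compound 2 `CC(=O)Nc1cccc(-c2ccc(C(=O)N(Cc3cccc(OCCCCCC(=O)O)c3)C(C)C)cc2)c1`: > 26000 nM

In an ADME assay on BJ cells (Homo sapiens) for cytotoxicity, read by CellTiter-Glo and resazurin assay, with a stated time of 72 h (a higher number here means that more compound is needed for the effect, a lower number that less compound is needed), compound 1 gives < 1.3 nM, a limit of the assay (the limit of < 1.3 nM in this assay, at which 1 of the 2 values shown sits). Compound 2 gives > 26000 nM, also a limit (the limit of > 26000 nM in this assay, at which 1 of the 2 values shown sits). Compound 2 thus stands at the high end of the two values shown. Among the compounds with values here, the single measured step is an at least 20000-fold higher number from compound 1 to compound 2 (4.30 log units; beyond the scatter). Compound 3 `CC(C)N(Cc1cccc(OCCCCCC(=O)O)c1)C(=O)c1ccc(-c2ccncc2)cc1` carries pyridin-4-yl in place of 3-acetamidophenyl on an aromatic carbon. The measured step changed the same aromatic carbon, with a very large shift; it shows the site is sensitive but does not fix the direction for pyridin-4-yl. A step of an at least 1.7-fold lower number from compound 2 to compound 3 (0.23 log units; that floor lies within the scatter) is expected, at most modest. Compound 3 is estimated at 15000 nM, within 2500 nM to 26000 nM.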

Compound 3, half-maximal effective concentration: > 26000 nM
Compound 3 was reported as a limit (the forecaster's own chance of this, stated with the estimate: 55%); middle value at least 1.7-fold (0.23 log units) away from the limit.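

In this assay, pyridin-4-yl on this aromatic carbon gives an at least 20000-fold higher number from compound 1 to compound 3 (4.30 log units; beyond the scatter), so the shift seen with 3-acetamidophenyl is not confined to that one group. Among the three compounds, only naphthalen-1-yl gives the low reading. The step between compound 2 and compound 3 cannot be read, as both values are the same limit: the limit of > 26000 nM in this assay, at which 2 of the 3 values shown sit.

Open, on these data alone, is whether any aryl group here reads between the two limits. Plain phenyl, naphthalen-2-yl or a phenyl carrying an amine would test how far the low reading extends beyond naphthalen-1-yl.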